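A few compounds are considered here, and "the series" means these few. Any claim that something is new, unique, unknown or untested is made for them only; others in the source may bear on it.

Measured in a functional assay on IMR-32 cells (Homo sapiens) for antiproliferative activity, read by MTT assay; a lower number here means a stronger inhibitor, a higher number a weaker inhibitor:
- compound 1 `CC1(C)CCc2c(ccc(C(=O)/C=C/c3ccc(OCc4cn(-c5ccc(Cl)cc5)nn4)cc3)c2O)O1`: "not active" (no number reported)
- compound 2 `Cc1c(-n2cc(COc3ccc(/C=C/C(=O)c4ccc5c(c4O)CCC(C)(C)O5)cc3)nn2)cccc1[N+](=O)[O-]`: 73500 nM

Among the compounds with values here, compound 2 at 73500 nM holds the only number in this small series, so it can be ranked against nothing. Compound 1 gives "not active" (no number reported), with no number reported.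

The next compound to be tested is compound 3 `CC(=O)c1ccc(-n2cc(COc3ccc(/C=C/C(=O)c4ccc5c(c4O)CCC(C)(C)O5)cc3)nn2)cc1`, which has 4-acetylphenyl in place of 2-methyl-3-nitrophenyl on an aromatic nitrogen. Within the data shown here, no measured step between two compounds is available to scale this change. The expectation rests only on compound 2 at 73500 nM and on the similar size of the two groups. The expected change in this assay is small, a 1.6-fold lower number from compound 2 to compound 3 (0.21 log units; within the scatter), with nothing foreseen beyond the scatter and only a slight lean toward a lower number. For compound 3 the estimated value is 45000 nM, with an expected range of 12000 nM to 120000 nM.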

Compound 3, half-maximal inhibitory concentration: 89600 nM
The estimate for compound 3 lay 2.0-fold (0.30 log units) below the measured number; measured number inside the range.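

In this assay, 4-acetylphenyl in place of 2-methyl-3-nitrophenyl on the aromatic nitrogen gives a 1.2-fold higher number from compound 2 to compound 3 (0.09 log units; within the scatter) and so leaves the two groups unseparated. This first readable step at the position shows that the nitro and methyl substituents can be exchanged for an acetyl group, at a different place on the phenyl ring, without a change beyond the scatter. Compound 1 has no number, so steps to it cannot be read, and no measurement on these groups is available to explain the result.

Within the data shown here, with only two numbers, the series leaves open how far this position can move the value at all. A carboxylic acid or an amine on the phenyl ring, or a longer alkyl chain in place of that ring, could test whether any group here takes the number beyond the scatter.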